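The source may report more compounds than this note shows. Statements on the series, on what has been measured and on what is new or still open speak of the compounds shown alone.

Within the data shown here, in a functional assay on HT-29 cells (Homo sapiens) for antiproliferative activity, read by MTT assay, with a stated time of 24 h (a higher number here means a weaker inhibitor, a lower number a stronger inhibitor), the three compounds measured so far all sit at a limit of the assay rather than at a number. Compound 1 `COc1ccc(C(=O)/C=C/c2cc(OC)c(OC)c(OC)c2)c2c1C=CC(C)(C)O2` gives > 10000 nM, which is a limit. Compound 2 `COc1ccc(C(=O)/C=C/c2ccc(F)cc2)c2c1C=CC(C)(C)O2` gives > 10000 nM, again a limit. Compound 3 `COc1ccc(C(=O)/C=C/c2ccc(N(c3ccccc3)c3ccccc3)cc2)c2c1C=CC(C)(C)O2` gives > 10000 nM, also a limit. Among the measured compounds shown here, compound 2 therefore stands where every value shown stands, at the limit of > 10000 nM in this assay, at which 3 of the 3 values shown sit, and no step between two measured compounds can be read from these data.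

Compound 4 `COc1ccc(C(=O)/C=C/c2cc(Cl)ccc2O)c2c1C=CC(C)(C)O2` shares the core of compound 2 and differs from it in one place: 5-chloro-2-hydroxyphenyl in place of 4-fluorophenyl on a double-bonded chain carbon bound to a double-bonded chain carbon. For the measured compounds named here, because the three measured values are all limits, as the limit of > 10000 nM in this assay, at which 3 of the 3 values shown sit, states, the data give no step that could be carried over to this change. The expected step in this assay from compound 2 to compound 4 is a step that the limit leaves unreadable from compound 2 to compound 4, that is, no movement beyond the usual scatter, with the most likely outcome being yet another limit rather than a number. Taking the change on its own, compound 4 is estimated at 20000 nM in this assay, within a range from 5000 nM to 80000 nM.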

Compound 4, half-maximal inhibitory concentration: 4970 nM
Compound 4: middle estimate off by 4.0-fold (0.60 log units), on the high side; measured number below the stated range.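

In this assay, compound 4 is the only compound shown so far that gives a number rather than a limit, so a group on a double-bonded chain carbon bound to a double-bonded chain carbon can bring the shared core into the readable range. Putting 5-chloro-2-hydroxyphenyl in place of 4-fluorophenyl gives an at least 2.0-fold lower number from compound 2 to compound 4 (0.30 log units; that floor lies within the scatter), and this is only a floor, as the true size of the step stays hidden behind the limit of compound 2: the limit of > 10000 nM in this assay, at which 3 of the 4 values shown sit.

The entering group also brings one hydrogen-bond donor and one hydrogen-bond acceptor that 4-fluorophenyl lacks, but the chlorine and the hydroxyl enter together, so this single change cannot be divided between them.

Which of the two matters more stays open, as none of the compounds shown carries a ring with only one of them. Also open, on these data alone, is how an amine or a carboxylic acid in place of that hydroxyl would read in this assay.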